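Fluorine added to the oxadiazole side chain of compound 2

This account rests on a few compounds, and the source may have more. Where it says the series, first, only, none or still open, it means among the compounds named here.

Of the compounds shown here, two sharing one core have been measured so far. Compound 1 `Cc1nc(S(C)(=O)=O)ccc1Oc1ncnc(OC2CCN(C(=O)O[C@H](C)C(F)(F)F)CC2)c1F` gives 9.2 nM in a functional assay on isolated protein for inhibition of Glucose-dependent insulinotropic receptor (Homo sapiens), read by HTRF and cAMP accumulation (on this read-out higher numbers stand for an effect only at larger amounts of compound and lower numbers for an effect already at smaller amounts), while compound 2 `Cc1nc(S(C)(=O)=O)ccc1Oc1ncnc(OC2CCN(C(=O)c3noc(C(C)C)n3)CC2)c1F` gives 21.2 nM. Among the measured compounds shown here, the step of a 2.3-fold higher number from compound 1 to compound 2 (0.36 log units; beyond the scatter) is the only measured step, and it places compound 2 as the higher of the two numbers, with compound 1 as its only neighbour.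

Compound 3 `Cc1nc(S(C)(=O)=O)ccc1Oc1ncnc(OC2CCN(C(=O)c3noc(C(C)(C)F)n3)CC2)c1F` is not yet measured. It differs from compound 2 in one place: fluoro in place of hydrogen on a saturated chain carbon bound to an aromatic carbon and two saturated chain carbons. For the measured compounds named here, the one step measured so far swaps a whole group on the carbonyl carbon and does not touch the isopropyl chain, so no measured step bears directly on this change. With nothing else to go on, compound 3 is expected to sit close to compound 2, with a step of a 1.1-fold lower number from compound 2 to compound 3 (0.03 log units; within the scatter) that may well lie within the scatter of repeated measurements in this assay. Compound 3 is therefore estimated at 20 nM, with a range from 8 nM to 50 nM.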

Compound 3, half-maximal effective concentration: 14 nM
Compound 3: the middle estimate sits 1.4-fold (0.15 log units) above what was measured; low and high end bracket the measured number.
By their numbers in this assay, from the lowest: compounds 1, 3 and 2 (each within the scatter of the next, the first and the last beyond it).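

In this assay, fluoro in place of hydrogen on the saturated chain carbon bound to an aromatic carbon and two saturated chain carbons, which turns isopropyl into 1-fluoro-1-methylethyl, gives a 1.5-fold lower number from compound 2 to compound 3 (0.18 log units; within the scatter), so this position tolerates the fluorine atom with no difference that stands out from repeated measurement. Swapping the 1-(trifluoromethyl)ethoxy group on the carbonyl carbon for the oxadiazole gives a 2.3-fold higher number from compound 1 to compound 2 (0.36 log units; beyond the scatter) with the isopropyl chain, but a 1.5-fold higher number from compound 1 to compound 3 (0.18 log units; within the scatter) with the 1-fluoro-1-methylethyl chain, so only the first of these two swaps stands clear of the scatter, and that contrast rests on one small fluoro step and should be read with care. No measurement at hand explains these numbers.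

On this chain carbon the compounds shown carry only hydrogen or fluoro, so the outcome with a hydroxyl or methoxy group there remains open, as does a longer chain in place of 1-fluoro-1-methylethyl. A single pair also leaves open whether fluoro in place of hydrogen would give a similar step on another core.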